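The source may report more compounds than this note shows. Statements on the series, on what has been measured and on what is new or still open speak of the compounds shown alone.

Measured so far in a functional assay on ASPC1 cells (Homo sapiens) for inhibition, read by MTT assay, with a stated time of 72 h; on this read-out lower numbers stand for stronger inhibition of growth and higher numbers for weaker inhibition of growth:
Compound 1 `O=S(=O)(NCCCNCc1cccc2ccccc12)c1cc(C(F)(F)F)cc(C(F)(F)F)c1` gives 21000 nM.
Compound 2 `O=S(=O)(NCCCNCc1ccc(Cl)cc1)c1cc(C(F)(F)F)cc(C(F)(F)F)c1` gives 3000 nM.
Compound 3 `COc1ccc(CNCCCNS(=O)(=O)c2cc(C(F)(F)F)cc(C(F)(F)F)c2)cc1OC` gives 6400 nM.

Compound 3 stands second highest of the three numbers; its nearest neighbour is compound 2, with a 2.1-fold higher number from compound 2 to compound 3 (0.33 log units; beyond the scatter), and its furthest is compound 1, with a 3.3-fold lower number from compound 1 to compound 3 (0.52 log units; beyond the scatter). Compound 4 `CC(C)(C)c1ccc(CNCCCNS(=O)(=O)c2cc(C(F)(F)F)cc(C(F)(F)F)c2)cc1` is not yet measured; the change from compound 3 is 4-(tert-butyl)phenyl in place of 3,4-dimethoxyphenyl on a saturated chain carbon bound to an amine nitrogen. For the measured compounds named here, the steps that bear on it are a 7.0-fold lower number from compound 1 to compound 2 (0.85 log units; beyond the scatter) and a 3.3-fold lower number from compound 1 to compound 3 (0.52 log units; beyond the scatter), both replacing naphthalen-1-yl with a substituted phenyl, and a 2.1-fold higher number from compound 2 to compound 3 (0.33 log units; beyond the scatter), which ranks the two phenyl variants. A 4-(tert-butyl)phenyl is expected to land nearer compound 2 than compound 1, so a modest downward step is expected, a 1.8-fold lower number from compound 3 to compound 4 (0.26 log units; within the scatter). Compound 4 is estimated at 3500 nM, with a range from 1500 nM to 9000 nM.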

Compound 4, concentration for 50% growth inhibition: 2700 nM
The estimate for compound 4 lay 1.3-fold (0.11 log units) above the measured number; low and high end bracket the measured number.
By their numbers in this assay, from the lowest: compounds 4 and 2 (each within the scatter of the next); then compound 3; then compound 1.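

In this assay, 4-(tert-butyl)phenyl, with no hydrogen-bond acceptors, gives a 2.4-fold lower number from compound 3 to compound 4 (0.37 log units; beyond the scatter), so the oxygens of 3,4-dimethoxyphenyl are not required at this position for growth inhibition. Tert-butyl in place of chloro on an aromatic carbon leaves the number level, a 1.1-fold lower number from compound 2 to compound 4 (0.05 log units; within the scatter), while naphthalen-1-yl stays clearly the weakest, with a 7.8-fold lower number from compound 1 to compound 4 (0.89 log units; beyond the scatter). No measurement at hand accounts for these differences.

Still open, going by these compounds, is whether an amine or a carboxylic acid on the phenyl ring, or a longer chain in the shared core, would shift the number.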